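A few compounds are considered here, and "the series" means these few. Any claim that something is new, unique, unknown or untested is made for them only; others in the source may bear on it.

Measured in a toxicity assay on HEK-293T cells (Homo sapiens) for cytotoxicity, read by MTT assay, with a stated time of 72 h; a higher number here means a weaker inhibitor, a lower number a stronger inhibitor:

compound 1 `CN1CCN(CCCCCCn2c3c(c4ccccc42)C(=O)c2c[n+]([O-])c4ccccc4c2C3=O)CC1`: 5800 nM
compound 2 `CC1(C)OCC(Cn2cc(Cn3c4c(c5ccccc53)C(=O)c3c[n+]([O-])c5ccccc5c3C4=O)nn2)O1`: 5510 nM
compound 3 `CN(C)CCCCn1c2c(c3ccccc31)C(=O)c1c[n+]([O-])c3ccccc3c1C2=O`: 520 nM

Among these three, compound 2 gives the second highest number. Its nearest neighbour is compound 1, whose value lies within the scatter of that of compound 2, so the two cannot be told apart. Going by the values given here, compound 3 gives a much lower number than compound 2, and the only step with a single change, an 11-fold lower number from compound 1 to compound 3 (1.05 log units; beyond the scatter), concerns a change of the amine at the end of the chain, not a stereocentre.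

Compound 4 `CC1(C)OC[C@@H](Cn2cc(Cn3c4c(c5ccccc53)C(=O)c3c[n+]([O-])c5ccccc5c3C4=O)nn2)O1` is not yet measured. It differs from compound 2 as follows: the two compounds have the same atoms and bonds; at least one stereo element is drawn with a configuration in one of them and without one in the other: 1 of 1 stereo elements differ; a stereocentre at a saturated ring carbon is drawn without a configuration in compound 2 and R in compound 4. Among the compounds with values here, no measured step here involves a stereocentre, so nothing in the data indicates a change in this assay, and a step within the scatter is expected, a 1.0-fold lower number from compound 2 to compound 4 (0.00 log units; within the scatter). Compound 4 is therefore estimated to give 5500 nM, within a range from 2500 nM to 12000 nM.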

Compound 4, half-maximal inhibitory concentration: 6020 nM
The estimate for compound 4 lay 1.1-fold (0.04 log units) below the measured number; low and high end bracket the measured number.
By their numbers in this assay, from the lowest: compound 3; then compounds 2, 1 and 4 (each within the scatter of the next).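

In this assay, drawing the saturated ring carbon with the R configuration produces no change that can be told apart: a 1.1-fold higher number from compound 2 to compound 4 (0.04 log units; within the scatter). This is the first step shown that touches a stereocentre, and it stands in contrast to the change of amine at the end of the chain, where an 11-fold lower number from compound 1 to compound 3 (1.05 log units; beyond the scatter). Even so, this step is not a direct comparison of R with S, because the difference between the two structures is limited to this: the fact that one of compounds 2 and 4 is drawn with a defined configuration and the other without, at the place where they differ.

As far as these compounds go, how the S form would compare in this assay therefore stays open, so it cannot yet be said that configuration at this carbon is without consequence. Also open, from the compounds shown here alone, is how a diol with two free hydroxyl groups, in place of the ring that carries this carbon, would behave in this assay.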